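The compounds below may be only part of what the source reports. "The series", "measured", "known", "first", "only" and "open" are said of these compounds alone.

Compound 3, with the structure `CN1CCN(c2ccc(C3=NN(S(=O)(=O)c4ccc(Br)cc4)C(c4ccc(N(C)C)cc4)C3)cc2)CC1`, stands second highest of the three measured compounds in a functional assay on NCI-H1975 cells (Homo sapiens) for inhibition, read by sulforhodamine B assay, tested at 10 uM (a higher number here means more inhibition at the concentration tested (going by the name of the read-out), a lower number less inhibition), where compound 3 gives 70.8%. Above it stands compound 2, `CN1CCN(c2ccc(C3=NN(S(=O)(=O)c4ccc(F)cc4)C(c4ccc(N(C)C)cc4)C3)cc2)CC1`, which in this assay gives 95.7%; below it stands compound 1, `Cc1ccc(S(=O)(=O)N2N=C(c3ccc(N4CCN(C)CC4)cc3)CC2c2ccc(N(C)C)cc2)cc1`, which in this assay gives 38.1%. The three differ only in one group on an aromatic carbon, and the measured steps are a number 57.6 percentage points higher from compound 1 to compound 2 (beyond the scatter), a number 32.7 percentage points higher from compound 1 to compound 3 (beyond the scatter) and a number 24.9 percentage points lower from compound 2 to compound 3 (beyond the scatter).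

Compound 4, `CN1CCN(c2ccc(C3=NN(S(=O)(=O)c4ccc(C(F)(F)F)cc4)C(c4ccc(N(C)C)cc4)C3)cc2)CC1`, differs from compound 3 by the change (trifluoromethyl in place of bromo on an aromatic carbon). All three measured steps bear on this position: two large rises from the methyl compound and one modest fall from fluoro to bromo. Within the data shown here, no trifluoromethyl compound has been measured, so the direction of a further exchange at this position cannot be read from the numbers; the three measured groups span a wide band, and a fourth group is expected to land inside that band. The account therefore expects a step of a number 8.8 percentage points lower from compound 3 to compound 4 (within the scatter) from compound 3 to compound 4 in this assay, a change not beyond the scatter. For compound 4 the estimate in this assay is 62%, within a range from 30% to 90%.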

Compound 4, a percentage reported as inhibition, at one concentration (the size of the read-out at that concentration, not a potency): 18.9%
Compound 4: the middle estimate sits 43.1 percentage points above what was measured, outside the stated range (below it).
By their numbers in this assay, from the lowest: compound 4; then compound 1; then compound 3; then compound 2.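

In this assay the trifluoromethyl group does not continue the rise seen on leaving methyl: it gives a number 51.9 percentage points lower from compound 3 to compound 4 (beyond the scatter) and, against the fluoro compound, a number 76.8 percentage points lower from compound 2 to compound 4 (beyond the scatter), so two groups that both carry fluorine stand at opposite ends of the four measured values. It also gives a number 19.2 percentage points lower from compound 1 to compound 4 (beyond the scatter), which shows that methyl does not mark the low end at this position and that compound 4 is the least inhibiting of the four, with every step to the others beyond the scatter. The numbers at this position therefore follow no simple ranking from the halogens onward, as replacing one para substituent can move the read-out either side of methyl, but nothing shown explains this order.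

What the compounds shown leave open is where a chloro, methoxy or nitrile group on this aromatic carbon would fall among these values. On these data alone, it also remains open whether the same order would hold if a morpholine stood in place of the methylpiperazine in the shared core.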